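Cyano in place of pyridinyl on an alkynyl thiazole

The source may report more compounds than this note shows. Statements on the series, on what has been measured and on what is new or still open speak of the compounds shown alone.

Measured compounds:
compound 1, `Cc1cccc(NC(=O)c2cccc(C#N)c2)n1`, 490 nM
compound 2, `Cc1nc(C#Cc2cc(F)cc(-c3cccnc3)c2)cs1`, 4.83 nM

Within the data shown here, in an in vitro functional assay on HEK293-A cells for antagonist activity at metabotropic glutamate receptor 5 (Rattus norvegicus), read by fluorescence and calcium flux, with a stated time of 140 s (a higher number here means a weaker inhibitor, a lower number a stronger inhibitor), compound 2 gives 4.83 nM, the lowest of the two numbers so far. Compound 1, built on a different core, gives 490 nM in this assay, a gap well beyond the scatter. Compound 3, `Cc1nc(C#Cc2cc(F)cc(C#N)c2)cs1`, has not been measured; it differs from compound 2 in one place: cyano in place of pyridin-3-yl on an aromatic carbon, meta to a fluoro group and meta to a group of 8 heavy atoms. Among the measured compounds shown here, no step between measured compounds is available to calibrate this change, and compound 1 carries a cyano group on another core, so it cannot be read as a guide. Compound 3 is therefore expected to sit near compound 2, with a modest loss at most, a step of a 3.1-fold higher number from compound 2 to compound 3 (0.49 log units; beyond the scatter) being estimated. For compound 3 the estimate in this assay is 15 nM, within a range from 3 nM to 70 nM.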

Compound 3, half-maximal inhibitory concentration: 0.813 nM
Beside the measured number, compound 3's estimate is 18-fold (1.27 log units) above it; the whole stated range lies above it.
By their numbers in this assay, from the lowest: compound 3; then compound 2; then compound 1.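

In this assay, among these compounds, replacing pyridin-3-yl with cyano on this aromatic carbon, meta to a fluoro group, gives a 5.9-fold lower number from compound 2 to compound 3 (0.77 log units; beyond the scatter), the first step that can be read at this position. On the shared core, then, the six-membered aromatic ring is not needed for strong inhibition: a cyano group of 2 heavy atoms and no ring gives the lower number, while the count of hydrogen-bond acceptors stays the same. Nothing available explains why this change lowers the number.

This single step cannot separate the loss of the ring from the arrival of the nitrile itself. The compounds shown leave open how a chlorine atom, a methyl group or a carboxamide would fare at this position, and whether the fluoro group contributes to the result.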